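A few compounds are considered here, and "the series" means these few. Any claim that something is new, unique, unknown or untested is made for them only; others in the source may bear on it.

Measured so far in a physicochemical assay for solubility, in phosphate buffer, at pH 6.5; a higher number here means a more soluble compound, a lower number a less soluble compound:
Compound 1 `CCOc1cc(CN2CCC(NC(=O)c3ccc(NC)nc3)CC2)cc(OCC)c1F`: 330 ug/mL
Compound 2 `CCOc1cc(CN2CCC(NC(=O)c3ccc(NC(C)C)nc3)CC2)cc(OCC)c1F`: > 520 ug/mL (a limit of the assay)

Compound 2 stands at > 520 ug/mL, which is a limit of the assay and not a number. Compound 3 `CCOc1cc(CN2CCC(NC(=O)c3cncc(C)c3)CC2)cc(OCC)c1F` carries 5-methylpyridin-3-yl in place of 6-(isopropylamino)pyridin-3-yl on a carbonyl carbon. Among the compounds with values here, the one measured step is an at least 1.5-fold higher number from compound 1 to compound 2 (0.19 log units; that floor lies within the scatter). It is isopropyl in place of methyl on a nitrogen on an aromatic ring, so it is the nearest guide but does not cover this replacement. Resting on that step alone, no step beyond the scatter is expected in this assay. The estimated size is an at least 1.1-fold lower number from compound 2 to compound 3 (0.06 log units; that floor lies within the scatter). For compound 3 the estimated value is 450 ug/mL, with an expected range of 200 ug/mL to 800 ug/mL.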

Compound 3, solubility: 443 ug/mL
Beside the measured number, compound 3's estimate is 1.0-fold (0.01 log units) above it; the range from low to high includes it.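

In this assay, the position on the carbonyl carbon now has a group with no nitrogen substituent on the ring: 5-methylpyridin-3-yl, with 0 hydrogen-bond donors, in place of 6-(methylamino)pyridin-3-yl gives a 1.3-fold higher number from compound 1 to compound 3 (0.13 log units; within the scatter). Compound 2 stands at > 520 ug/mL, which is a limit of the assay and not a number. The replacement of its 6-(isopropylamino)pyridin-3-yl gives an at least 1.1-fold lower number from compound 2 to compound 3 (0.06 log units; that floor lies within the scatter), and this remains a floor only because of that limit: the limit of > 520 ug/mL in this assay, at which 1 of the 3 values shown sits.

As far as these compounds go, whether a carboxylic acid or a longer chain in place of the methyl on 5-methylpyridin-3-yl would move the reading beyond the scatter remains open. From the compounds shown here alone, the full size of every step involving compound 2 also remains open.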